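Compound 4 Expected From the Step Off Compound 2

A few compounds are considered here, and "the series" means these few. Any claim that something is new, unique, unknown or untested is made for them only; others in the source may bear on it.

Three compounds have measured values: compound 1 `O=C(CSc1nc(-c2ccccc2)c(C(=O)O)c(=O)[nH]1)Nn1c(COc2ccc(Cl)cc2Cl)nc2ccccc2c1=O`, compound 2 `N#Cc1c(Cl)nc(SCC(=O)Nn2c(COc3ccc(Cl)cc3Cl)nc3ccccc3c2=O)nc1-c1ccc(Cl)cc1` and compound 3 `N#Cc1c(Cl)nc(SCC(=O)Nn2c(COc3ccc(Cl)cc3Cl)nc3ccccc3c2=O)nc1-c1ccc(O)cc1`. In a functional assay on the whole organism (strain albino) for inhibition, with Rattus norvegicus as the target, read by paw edema, with stated times of 1 h and 3 h, at a dose of 100 mg/kg by the oral route (a higher number here means a stronger effect of the compound at the dose given, a lower number a weaker effect), compound 2 gives 68.4%, the second highest of the three numbers; compound 1 gives 64.9% and compound 3 gives 73.7%, both within the scatter of compound 2. Within the data shown here, the one measured step, a number 5.3 percentage points higher from compound 2 to compound 3 (within the scatter), is hydroxy in place of chloro on an aromatic carbon. Compound 4 `N#Cc1c(Nc2ccc(O)cc2)nc(SCC(=O)Nn2c(COc3ccc(Cl)cc3Cl)nc3ccccc3c2=O)nc1-c1ccc(Cl)cc1` differs from compound 2 by (4-hydroxyphenyl)amino in place of chloro on an aromatic carbon. Among the measured compounds shown here, no measured step touches that aromatic carbon, and the only measured step lies within the scatter, so in this assay no step beyond the scatter is expected; the expected step is a number 1.6 percentage points higher from compound 2 to compound 4 (within the scatter). Compound 4 is therefore estimated at 70%, between 58% and 82%.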

Compound 4, a percentage reported as inhibition, in the whole organism at one dose (the size of the read-out at that dose, not a potency): 91.2%
For compound 4 the middle estimate is 21.2 percentage points below the measured one; the measured number lies above the stated range.
By their numbers in this assay, from the lowest: compounds 1, 2 and 3 (each within the scatter of the next); then compound 4.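

In this assay, the aromatic carbon next to the ring nitrogen and ortho to a cyano group proves responsive: (4-hydroxyphenyl)amino in place of chloro gives a number 22.8 percentage points higher from compound 2 to compound 4 (beyond the scatter), the only step shown that lies beyond the scatter. The step on the 4-chlorophenyl group, a number 5.3 percentage points higher from compound 2 to compound 3 (within the scatter), did not show this. No available evidence bears on the reason for this gain. The compounds shown leave open whether the gain needs the hydroxy group or only the amino link. Phenylamino or a small amine such as methylamino at this carbon would separate the two.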